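The source may hold more compounds than are shown below. What is called first, only, known or untested is meant among the compounds shown, and "the series" means these compounds.

In a functional assay on Raji cells (Homo sapiens) for inhibition, read by MTT assay, with a stated time of 96 h (a higher number here means that more compound is needed for the effect, a lower number that less compound is needed), compound 1 (`CC(C)Cn1c(=O)n(C)c(=O)c2nc(C(=O)NCCCO)c(Cc3cccc4ccccc34)nc21`) gives > 10000 nM, which is a limit and not a number. Compound 2 (`CC(C)Cn1c(=O)n(C)c(=O)c2nc(-c3c(CCCO)nnn3C)c(Cc3cccc4ccccc34)nc21`) gives > 10000 nM, also a limit. Among the measured compounds shown here, compound 2 therefore shares (the limit of > 10000 nM in this assay, at which 2 of the 2 values shown sit), and the only measured step, a step that the two limits leave unreadable from compound 1 to compound 2, offers no size to carry forward. Compound 3 (`COCCCCCc1nc2c(=O)n(C)c(=O)n(CC(C)C)c2nc1Cc1cccc2ccccc12`) has 5-methoxypentyl in place of 4-(3-hydroxypropyl)-1-methyl-1H-1,2,3-triazol-5-yl on an aromatic carbon. With so little to go on, the expected change is a loose guess that leans towards a lower number, an at least 3.3-fold lower number from compound 2 to compound 3 (0.52 log units; beyond the scatter). For compound 3 the estimated value is 3000 nM, with an expected range from 150 nM to 10000 nM.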

Compound 3, half-maximal effective concentration: 5780 nM
Estimate against measurement, compound 3: 1.9-fold (0.28 log units) below; measured number inside the range.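

Among the compounds shown here, compound 3 is the first compound here with a 5-methoxypentyl chain at this position, with no ring and 0 hydrogen-bond donors in that group, and the first to give a number rather than a limit in this assay. The change reads as an at least 1.7-fold lower number from compound 2 to compound 3 (0.23 log units; that floor lies within the scatter), and the change from the amide as an at least 1.7-fold lower number from compound 1 to compound 3 (0.23 log units; that floor lies within the scatter). Both sizes are only floors, set by the limit of the other compound: the limit of > 10000 nM in this assay, at which 2 of the 3 values shown sit.

As far as these compounds go, whether the ether oxygen or the chain itself matters stays open. A plain pentyl chain, a shorter chain or an amine at the chain end could separate these.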